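This account rests on a few compounds, and the source may have more. Where it says the series, first, only, none or still open, it means among the compounds named here.

The series is followed in an assay on isolated protein for inhibition of Rho-associated protein kinase 2 (Homo sapiens), read by scintillation counting, radiometric assay and 33P incorporation, with a stated time of 40 min, in the presence of a further agent that is not named here; a lower number here means a stronger inhibitor, a higher number a weaker inhibitor. For the measured compounds named here, compound 2, `O=C(COc1ccc2c(=O)ccoc2c1)Nc1cccc(NC(=O)c2ccc(Br)cc2)c1`, gives 49 nM in this assay and is the only compound of the set with a numerical result. Compound 1, `COc1ccc(OCC(=O)Nc2cccc(NC(=O)c3ccc(N(C)C)cc3)c2)cc1OC`, is reported in this assay only as a limit of > 10000 nM. Going by the values given here, that limit is the one point of evidence on the measured compounds: the limit of > 10000 nM in this assay, at which 1 of the 2 values shown sits.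

Compound 3, `Nc1cccc(C(=O)Nc2cccc(NC(=O)COc3ccc4c(=O)ccoc4c3)c2)c1`, has not been measured in this assay. It differs from compound 2 in one place: 3-aminophenyl in place of 4-bromophenyl on a carbonyl carbon. Among the compounds with values here, no pair of measured compounds shows this change, so no measured step can be pointed to, and the direction of the change rests on no evidence in the set. Compound 3 is therefore expected to lie close to compound 2, with a step from compound 2 to compound 3 of a 2.4-fold higher number from compound 2 to compound 3 (0.39 log units; beyond the scatter), which may or may not go beyond the scatter of repeated measurements. In this assay compound 3 is estimated at 120 nM, with the expected range running from 30 nM to 500 nM.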

Compound 3, half-maximal inhibitory concentration: 58 nM
Compound 3: the middle estimate sits 2.1-fold (0.32 log units) above what was measured; measured number inside the range.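

The position on the carbonyl carbon now has its first measured step in this assay, where 3-aminophenyl in place of 4-bromophenyl gives a 1.2-fold higher number from compound 2 to compound 3 (0.07 log units; within the scatter) and so leaves the two compounds indistinguishable. Within this pair, the bromine of 4-bromophenyl is therefore not needed to keep the number at this level, and the entering group's hydrogen-bond donor and hydrogen-bond acceptor, which the leaving group lacks, come with no measurable step. No measured fact in the set bears on why the two groups give such similar numbers.

This single pair changes the identity of the group and where it sits on the ring together, leaving open whether a plain phenyl, 4-aminophenyl, 3-bromophenyl or a phenyl ring carrying a carboxylic acid would hold the number in this assay. Compound 1 gives > 10000 nM, which is a limit, and because it differs from the other compounds in more than one place, it leaves open which of its parts accounts for that result.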